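Hydroxyl in Place of Amine on the Side Chain

A few compounds are considered here, and "the series" means these few. Any claim that something is new, unique, unknown or untested is made for them only; others in the source may bear on it.

Compound 1 `CN(C)CCn1c(N)c(-c2nc3ccccc3[nH]2)c2nc(C#N)c(C#N)nc21` gives 8880 nM in a functional assay on HeLa cells (Homo sapiens) for antiproliferative activity, read by MTT assay, with a stated time of 48 h (a lower number here means a stronger inhibitor, a higher number a weaker inhibitor), the lower of the two numbers shown, though compound 2 `CCN(CC)CCn1c(N)c(-c2nc3ccccc3[nH]2)c2nc(C#N)c(C#N)nc21` at 11600 nM sits within the scatter of it, as the step of a 1.3-fold higher number from compound 1 to compound 2 (0.12 log units; within the scatter) shows. Compound 3 `N#Cc1nc2c(-c3nc4ccccc4[nH]3)c(N)n(CCCO)c2nc1C#N` differs from compound 1 by hydroxymethyl in place of dimethylamino on a saturated chain carbon, two bonds along the chain from an aromatic nitrogen. Among the compounds with values here, the single measured step exchanges one amine for another and bears only loosely on this change; no hydroxyl-bearing compound has been measured here. The step of a 1.4-fold higher number from compound 1 to compound 3 (0.13 log units; within the scatter) is therefore expected to be small, in no clear direction. Compound 3 is estimated at 12000 nM, within 4000 nM to 40000 nM.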

Compound 3, half-maximal inhibitory concentration: > 50000 nM
Compound 3 was reported as a limit (the forecaster's own chance of this, stated with the estimate: 10%); middle value at least 4.1-fold (0.61 log units) away from the limit.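

Compound 3 is reported only as a limit, not as a number: the limit of > 50000 nM in this assay, at which 1 of the 3 values shown sits. Even so, replacing the amine with hydroxymethyl at this saturated chain carbon gives an at least 5.6-fold higher number from compound 1 to compound 3 (0.75 log units; beyond the scatter) and an at least 4.3-fold higher number from compound 2 to compound 3 (0.63 log units; beyond the scatter), both beyond the scatter. The swap of dimethylamino for diethylamino, by contrast, stayed within it, so the two amines read alike while 3-hydroxypropyl does not match either amine chain.

The compounds shown leave open whether the loss of the amine nitrogen or the arrival of the hydroxyl matters more. Going by these compounds, a morpholine or piperidine on the chain, or a longer chain carrying dimethylamino, remains untested here.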